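The compounds below may be only part of what the source reports. "The series", "measured", "known", "first", "only" and "open" are said of these compounds alone.

In a functional assay on the whole organism (spleen, spleen, strain LEW) for inhibition, with Rattus norvegicus as the target, with a stated time of 4 days, at a dose of 1 mg/kg by the oral route (a higher number here means more inhibition at the dose given (going by the name of the read-out), a lower number less inhibition), three compounds built on a shared core have been measured. Compound 1, `CCc1cc(CN2CC(C(=O)O)C2)sc1-c1cc(-c2ccc(Oc3ccccc3)cc2)on1`, gives 2%. Compound 2, `CCc1cc(CN2CC(C(=O)O)C2)sc1-c1nnc(-c2ccc(Oc3ccccc3)cc2)s1`, is reported only as "not active" (no number reported), with no number attached. Compound 3, `CCc1cc(CN2CC(C(=O)O)C2)sc1-c1ncc(-c2ccc(Oc3ccccc3)cc2)s1`, gives 42%. Of the two compounds with a number, compound 3 stands highest, and its gap to compound 1 lies beyond the usual scatter of repeated measurements.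

Compound 4, `CCc1cc(CN2CC(C(=O)O)C2)sc1-c1ncc(-c2ccc(OC(C)C)cc2)s1`, differs from compound 3 in a single place: isopropyl in place of phenyl on an oxygen on an aromatic ring. Within the data shown here, no two measured compounds differ only in this way, so nothing measured here shows how isopropyl in place of phenyl on an oxygen on an aromatic ring moves the inhibition. A moderate decrease is expected, because compound 3 alone supplies the starting value of 42% and the change removes the ring counted above. The expected step is a number 17 percentage points lower from compound 3 to compound 4 (beyond the scatter), with wide uncertainty. Compound 4 is estimated at 25%, within a range from 0% to 50%.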

Compound 4, a percentage reported as inhibition, in the whole organism at one dose (the size of the read-out at that dose, not a potency): 52%
Beside the measured number, compound 4's estimate is 27 percentage points below it; measured number outside the range, above it.
By their numbers in this assay, from the lowest: compound 1; then compounds 3 and 4 (each within the scatter of the next).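

Swapping phenyl for isopropyl on an oxygen on an aromatic ring gives a number 10 percentage points higher from compound 3 to compound 4 (within the scatter) in this assay, so this pair cannot be told apart in this read-out. At this position, then, the phenoxy group's six-membered aromatic ring is not needed for compound 4 to reach a value that matches that of compound 3. Isopropyl, with 3 heavy atoms and no ring, serves here as well as phenyl with its 6 heavy atoms, although this rests on a single pair of compounds.

As far as these compounds go, it remains open whether a methyl group, a longer chain such as hexyl, or a chain ending in an amine on the same oxygen would also match these two compounds. No measurement shown offers a reason why phenyl and isopropyl read alike here.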